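This account rests on a few compounds, and the source may have more. Where it says the series, first, only, none or still open, it means among the compounds named here.

Working notes on the cytotoxicity series.

Compound 1 `Cc1cc(C)cc(S(=O)(=O)c2c(C(=O)NCc3cccc(O)c3)[nH]c3ccc(Cl)cc23)c1` carries the shared core with the benzyl-type amide. In an ADME assay on MT4 cells (Homo sapiens) for cytotoxicity, read by MTT assay (a lower number here means that less compound is tolerated, a higher number that more compound is tolerated), compound 1 gives 27000 nM. Compound 2 `Cc1cc(C)cc(S(=O)(=O)c2c(C(=O)NC(C)c3cccc(O)c3)[nH]c3ccc(Cl)cc23)c1` differs by methyl in place of hydrogen on a saturated chain carbon bound to an amide-type nitrogen and an aromatic carbon; in this assay compound 2 gives 16000 nM. The step of a 1.7-fold lower number from compound 1 to compound 2 (0.23 log units; within the scatter) is small and carries no weight on its own.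

Compound 3 `Cc1cc(C)cc(S(=O)(=O)c2c(C(=O)NCC(=O)NCc3cccc(O)c3)[nH]c3ccc(Cl)cc23)c1` differs from compound 1 by (3-hydroxybenzyl)carbamoyl in place of 3-hydroxyphenyl on a saturated chain carbon bound to an amide-type nitrogen, so its core is the one stretched by the extra carbamoyl link. Compound 3 reaches only a limit of this assay, reported as > 47500 nM. The steps of an at least 1.7-fold higher number from compound 1 to compound 3 (0.24 log units; that floor lies within the scatter) and an at least 2.9-fold higher number from compound 2 to compound 3 (0.47 log units; beyond the scatter) are therefore floors rather than measured distances.

Compound 4 `Cc1cc(C)cc(S(=O)(=O)c2c(C(=O)NC(C)C(=O)NCc3cccc(O)c3)[nH]c3ccc(Cl)cc23)c1` is the unmeasured member. It differs from compound 3 by methyl in place of hydrogen on a saturated chain carbon bound to an amide-type nitrogen and a carbonyl carbon. This is the same kind of change as that from compound 1 to compound 2, but not the same: there the carbon also bound an aromatic carbon, here it also binds a carbonyl carbon. For the measured compounds named here, with the earlier step of a 1.7-fold lower number from compound 1 to compound 2 (0.23 log units; within the scatter) as the only guide, the expected step from compound 3 to compound 4 is about an at least 1.1-fold lower number from compound 3 to compound 4 (0.07 log units; that floor lies within the scatter). The expectation rests on compound 3 sitting at the limit, because the limit of > 47500 nM in this assay, at which 1 of the 3 values shown sits, means a small downward step may or may not bring compound 4 inside the measurable range. Compound 4 is estimated at 40000 nM, between 18000 nM and 95000 nM, with a real chance that only a limit is reported again.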

Compound 4, half-maximal cytotoxic concentration: 23800 nM
Beside the measured number, compound 4's estimate is 1.7-fold (0.23 log units) above it; the range from low to high includes it.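

In this assay, methyl in place of hydrogen on a saturated chain carbon bound to an amide-type nitrogen and a carbonyl carbon gives an at least 1.9-fold lower number from compound 3 to compound 4 (0.30 log units; that floor lies within the scatter), and set beside the earlier methyl step it reads: the same change on two cores in this assay, a 1.7-fold lower number (0.23 log units; within the scatter) from compound 1 to compound 2 and an at least 1.9-fold lower number (0.30 log units; that floor lies within the scatter) from compound 3 to compound 4; the limit leaves it open whether they differ The (3-hydroxybenzyl)carbamoyl change in place of 3-hydroxyphenyl, read on the methyl-bearing pair, gives a 1.5-fold higher number from compound 2 to compound 4 (0.17 log units; within the scatter), and set beside its counterpart on the other core it reads: the same change on two cores in this assay, an at least 1.7-fold higher number (0.24 log units; that floor lies within the scatter) from compound 1 to compound 3 and a 1.5-fold higher number (0.17 log units; within the scatter) from compound 2 to compound 4; the limit leaves it open whether they differ Neither comparison shows a change behaving differently from one core to the other, yet neither shows that it carries over unchanged, because compound 3 is a limit and not a number: the limit of > 47500 nM in this assay, at which 1 of the 4 values shown sits.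

Going by these compounds, whether ethyl or an amine in place of the methyl on that saturated chain carbon would give a step beyond the scatter remains open. Also open, on these data alone, is how the number would respond to a longer chain on the amide-type nitrogen of the shared core.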